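This account rests on a few compounds, and the source may have more. Where it says the series, first, only, none or still open, it means among the compounds named here.

The compounds share one core, an amide of a trifluoromethyl-bearing hydroxy acid with a substituted aniline, and all were examined in a functional assay (Cavia porcellus) with sulfonylurea receptors; K-ATP channels (Homo sapiens) as the target; on this read-out higher numbers stand for weaker inhibition and lower numbers for stronger inhibition. Compound 1 `CC(O)(C(=O)Nc1ccc(C#N)c(Sc2ccccc2)c1)C(F)(F)F` gives in this assay a value of 8300 nM. Compound 3 `COc1cc(NC(=O)C(C)(O)C(F)(F)F)ccc1S(=O)(=O)c1ccccc1` gives in this assay a value of 5900 nM. Compound 2 `CC(O)(C(=O)Nc1ccc(S(=O)(=O)c2ccc(C#N)cc2)cc1)C(F)(F)F` carries a 4-cyanophenyl sulfone, and in this assay compound 2 gives > 30000 nM, which is a limit of the assay and not a measured number. On the numbers shown, compound 2 therefore stands at the limit of > 30000 nM in this assay, at which 1 of the 3 values shown sits, with no inhibition recorded within the range of the assay.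

Compound 4 `CC(O)(C(=O)Nc1ccc(S(=O)(=O)c2ccc(Br)cc2)cc1)C(F)(F)F` is not yet measured. It differs from compound 2 in one place: bromo in place of cyano on an aromatic carbon. Going by the values given here, no measured pair in this set differs in only one place, so the size of this change cannot be read from a recorded step. The expectation is that the step of an at least 2.0-fold lower number from compound 2 to compound 4 (0.30 log units; that floor lies within the scatter) brings a modest gain in inhibition, since the other two compounds, compound 1 and compound 3, both gave numbers inside the range of the assay while compound 2 did not. Compound 4 is accordingly estimated at 15000 nM in this assay, within a range of 4000 nM to 60000 nM.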

Compound 4, half-maximal inhibitory concentration: > 30000 nM
Compound 4 gave a limit, no number (the forecaster's own chance of this, stated with the estimate: 35%); middle value at least 2.0-fold (0.30 log units) away from the limit.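

Compound 4 gives > 30000 nM, which is a limit of the assay and not a number. Going by these compounds alone, with compound 2 also at a limit, no step from one to the other can be read, and the two stand together: the limit of > 30000 nM in this assay, at which 2 of the 4 values shown sit. The compounds shown leave open whether bromo and cyano differ at all in this assay.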